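Benzyl for 4-hydroxycyclohexyl on the oxygen of compound 3

The source may hold more compounds than are shown below. What is called first, only, known or untested is meant among the compounds shown, and "the series" means these compounds.

Values in a functional assay on HeLa cells (Homo sapiens) for inhibition, read by CCK-8 assay, with a stated time of 48 h (a higher number here means a weaker inhibitor, a lower number a stronger inhibitor), for the measured compounds:
compound 1 `O=S(=O)(NCCNC(=S)Nc1cc(C(F)(F)F)cc(C(F)(F)F)c1)c1ccc(-c2ccccc2OCc2cccc(O)c2)s1` gives 14900 nM
compound 2 `O=[N+]([O-])c1ccc(NC(=S)NCCNS(=O)(=O)c2ccc(-c3ccccc3OCc3ccccc3)s2)cc1` gives 7100 nM
compound 3 `O=S(=O)(NCCNC(=S)Nc1cc(C(F)(F)F)cc(C(F)(F)F)c1)c1ccc(-c2ccccc2O[C@H]2CC[C@@H](O)CC2)s1` gives 10900 nM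

Compound 3 (10900 nM) lies within the scatter of both compound 1 and compound 2. Compound 4 `O=S(=O)(NCCNC(=S)Nc1cc(C(F)(F)F)cc(C(F)(F)F)c1)c1ccc(-c2ccccc2OCc2ccccc2)s1` differs from compound 3 in one place (benzyl in place of 4-hydroxycyclohexyl on an oxygen on an aromatic ring), and the rest of compound 3 is kept. Going by the values given here, the only measured step at this place (a 1.4-fold lower number from compound 1 to compound 3 (0.14 log units; within the scatter)) stayed within the scatter of this assay and so gives no reason to expect a large change. Compound 2, which also carries benzyl on that oxygen, reads 7100 nM in this assay and suggests at most a small drop. For compound 4 the expected step is small (a 1.1-fold lower number from compound 3 to compound 4 (0.06 log units; within the scatter)), with none expected beyond the scatter. Compound 4 is estimated at 9500 nM with an expected range of 4500 nM to 20000 nM.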

Compound 4, half-maximal inhibitory concentration: 4700 nM
Beside the measured number, compound 4's estimate is 2.0-fold (0.31 log units) above it; measured number inside the range.
By their numbers in this assay, from the lowest: compounds 4, 2, 3 and 1 (each within the scatter of the next, the first and the last beyond it).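

In this assay, the group on this oxygen now proves able to shift the number beyond the scatter: benzyl in place of 4-hydroxycyclohexyl gives a modest change (a 2.3-fold lower number from compound 3 to compound 4 (0.37 log units; beyond the scatter)), whereas the earlier step at this place stayed within it. Hydrogen in place of hydroxy on an aromatic carbon also gives a modest change (a 3.2-fold lower number from compound 1 to compound 4 (0.50 log units; beyond the scatter)), so compound 4 reads lower than both hydroxy-bearing compounds. Nothing available accounts for either step. As far as these compounds go, whether an amine or a carboxylic acid on the benzyl ring, or a longer chain between that ring and the oxygen, would move the number further remains open.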